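The source may hold more compounds than are shown below. What is called first, only, known or untested is meant among the compounds shown, and "the series" means these compounds.

Measured compounds in this series:
- compound 1, `COC(=O)c1ccc(NCc2cncn2Cc2ccc(C)cc2)cc1-c1ccccc1`, a toxicity assay on NIH3T3 cells (Mus musculus) for cytotoxicity, read by resazurin assay; a lower number here means that less compound is needed, a higher number that more compound is needed for the effect: 50000 nM
- compound 2, `COC(=O)c1ccc(NCc2cncn2Cc2ccc(C(C)(C)C)cc2)cc1-c1ccccc1`, this assay: "not determined" (no result reported)

For the measured compounds named here, compound 1 is the only member with a number in this assay; in that assay compound 1 gives 50000 nM. Compound 2 carries a 4-(tert-butyl)benzyl on the same core, but in this assay compound 2 gives "not determined" (no result reported), so it stands without a number and gives no anchor of its own.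

Compound 3, `COC(=O)c1ccc(NCc2cncn2Cc2cccc(Br)c2)cc1-c1ccccc1`, is the next compound to be run in this assay. Against compound 2 the change is 3-bromophenyl in place of 4-(tert-butyl)phenyl on a saturated chain carbon bound to an aromatic nitrogen. The rest of the molecule is unchanged. Going by the values given here, no measured pair in this set differs in one place, so there is no step to scale from; the only fixed point is compound 1, which also differs from compound 3 in this same outer position. Among the compounds with values here, with one measured compound and no step, the expectation is that compound 3 stays close to where compound 1 sits, with any difference likely within the usual scatter, in no preferred direction.

On that basis compound 3 is estimated in this assay at 50000 nM, with a range from 20000 nM to 100000 nM.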

Compound 3, half-maximal effective concentration: > 10000 nM
Compound 3 was reported as a limit (the forecaster's own chance of this, stated with the estimate: 35%); the middle value is on the limit's open side.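

In this assay compound 3 gives > 10000 nM, which is a limit and not a number. For the compounds shown here, no step from compound 1 to compound 3 can be read from this result. The compounds shown leave open whether 3-bromophenyl in place of 4-methylphenyl shifts the value in this assay, and where compound 2 stands relative to either compound.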